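This account rests on a few compounds, and the source may have more. Where it says the series, first, only, none or still open, it means among the compounds named here.

In a functional assay for inhibition (on this read-out higher numbers stand for weaker inhibition and lower numbers for stronger inhibition), compound 3 `CC(C)(C)c1cc(-c2cc(=O)c3ccc(OCCCS(=O)(=O)O)cc3o2)cc(C(C)(C)C)c1O` gives 500 nM, the second highest of three numbers: compound 2 `CC(C)(C)c1cc(-c2cc(=O)c3ccc(OCC(O)CO)cc3o2)cc(C(C)(C)C)c1O` gives 100 nM, and compound 1 `CCCCCCOc1ccc2c(=O)cc(-c3cc(C(C)(C)C)c(O)c(C(C)(C)C)c3)oc2c1` gives 5000 nM. Compound 4 `CC(C)(C)c1cc(-c2cc(=O)c3ccc(OCc4ccc(Cl)cc4)cc3o2)cc(C(C)(C)C)c1O` differs from compound 3 in one place: 4-chlorophenyl in place of 2-sulfoethyl on a saturated chain carbon bound to an oxygen on an aromatic ring. For the measured compounds named here, two measured steps touch this place. a 10-fold lower number from compound 1 to compound 3 (1.00 log units; beyond the scatter), and a 5.0-fold higher number from compound 2 to compound 3 (0.70 log units; beyond the scatter). Each of these put in or took out the sulfo group, and neither brought in an aromatic ring, so the new change is not directly covered. Because compound 1, which also carries no sulfo group there, gives 5000 nM at the weak end, compound 4 is expected to shift the same way, by a 4.0-fold higher number from compound 3 to compound 4 (0.60 log units; beyond the scatter). Compound 4 is therefore estimated at 2000 nM, within 500 nM to 8000 nM.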

Compound 4, half-maximal inhibitory concentration: 7000 nM
The estimate for compound 4 lay 3.5-fold (0.54 log units) below the measured number; measured number inside the range.
By their numbers in this assay, from the lowest: compound 2; then compound 3; then compounds 1 and 4 (each within the scatter of the next).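

Compared with the groups that give lower numbers, 4-chlorophenyl on this saturated chain carbon bound to an oxygen on an aromatic ring gives much weaker inhibition in this assay, both against 2-sulfoethyl (a 14-fold higher number from compound 3 to compound 4 (1.15 log units; beyond the scatter)) and against 1,2-dihydroxyethyl (a 70-fold higher number from compound 2 to compound 4 (1.85 log units; beyond the scatter)). Against pentyl, the aromatic ring makes no readable difference (a 1.4-fold higher number from compound 1 to compound 4 (0.15 log units; within the scatter)), so neither of these two groups stands apart from the other. No measurement here bears on why these groups differ.

On these data alone, it remains open whether an amine or a carboxylic acid at the end of this chain would match 1,2-dihydroxyethyl. As far as these compounds go, it is also open whether plain phenyl would read like 4-chlorophenyl.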